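Nitro in Place of Fluoro: Expectation for Compound 4

The source may hold more compounds than are shown below. What is called first, only, known or untested is meant among the compounds shown, and "the series" means these compounds.

Compound 1 `CC(=O)OC/C(=C\c1ccc(F)cc1)C(=O)c1ccccc1` and compound 2 `CC(=O)OC/C(=C\c1ccccc1F)C(=O)c1ccccc1` are built from the same atoms joined differently; the difference between their cores is 2-fluorophenyl in place of 4-fluorophenyl on a double-bonded chain carbon bound to a double-bonded chain carbon. In a functional assay on HBL-100 cells (Homo sapiens) for inhibition, read by sulforhodamine B assay, with a stated time of 48 h (on this read-out lower numbers stand for stronger inhibition of growth and higher numbers for weaker inhibition of growth), compound 1 gives 17000 nM, and compound 2 gives 17000 nM, so that no change at the digits printed from compound 1 to compound 2 (within the scatter). Compound 3 `CC(=O)OC/C(=C\c1ccc([N+](=O)[O-])cc1)C(=O)c1ccccc1` carries nitro in place of fluoro on an aromatic carbon; in this assay compound 3 gives 10000 nM, a step of a 1.7-fold lower number from compound 1 to compound 3 (0.23 log units; within the scatter). Compound 4 `CC(=O)OC/C(=C\c1ccccc1[N+](=O)[O-])C(=O)c1ccccc1`, not yet measured, differs from compound 2 by nitro in place of fluoro on an aromatic carbon. This is the same kind of change as that from compound 1 to compound 3, though not the same: there the nitro sits para to a large group, here ortho to a large group. Because a 1.7-fold lower number from compound 1 to compound 3 (0.23 log units; within the scatter) and because no change at the digits printed from compound 1 to compound 2 (within the scatter), a step of about a 1.5-fold lower number from compound 2 to compound 4 (0.19 log units; within the scatter) is expected in this assay. Compound 4 is therefore estimated at 11000 nM, within 5000 nM to 25000 nM.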

Compound 4, concentration for 50% growth inhibition: 26000 nM
Compound 4: middle estimate off by 2.4-fold (0.37 log units), on the low side, and the stated range ends below it.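

In this assay nitro in place of fluoro gives a 1.5-fold higher number from compound 2 to compound 4 (0.18 log units; within the scatter) on the core of compound 2, and the two cases compare as follows: the same change on two cores in this assay, a 1.7-fold lower number (0.23 log units; within the scatter) from compound 1 to compound 3 and a 1.5-fold higher number (0.18 log units; within the scatter) from compound 2 to compound 4, 2.6-fold (0.41 log units) apart, within the scatter of two such steps. Neither step stands clear of the scatter, so these two cores give no sign that the change behaves differently on one than on the other. This does not show that the change would carry over alike to other cores, nor that it does nothing on these two, since two pairs within the scatter settle neither point.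

The compounds shown leave open how an amine or a carboxylic acid in place of fluoro or nitro would read on the aromatic ring. They also leave open what a longer chain on the ester would do.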